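Adding Fluoro to Compound 3

The compounds below may be only part of what the source reports. "The series", "measured", "known", "first", "only" and "open" are said of these compounds alone.

In an ADME assay on HCT-116 cells (Homo sapiens) for antiproliferative activity (a lower number here means a stronger inhibitor, a higher number a weaker inhibitor), compound 3 (`COc1ccc(C(N)=O)cc1/C=C/c1ccccc1`) gives 36000 nM and lies within the usual scatter of both other measured compounds. Compound 1 (`CCc1ccc(OC)c(COc2ccc(Cl)c(C)c2)c1`) gives 43000 nM and compound 2 (`COc1ccc(C(N)=O)cc1/C=C\c1ccc(Cl)cc1`) gives 29000 nM so these numbers set no order among the three. Compound 4 (`COc1ccc(C(N)=O)cc1/C=C/c1ccc(F)cc1`) has fluoro in place of hydrogen on an aromatic carbon and is otherwise the same as compound 3. Within the data shown here, no measured pair differs in one place only, so the data offer no direct guide. Compound 3 at 36000 nM is the anchor, and no step beyond the scatter is expected in this assay in either direction. The estimated step of a 1.1-fold lower number from compound 3 to compound 4 (0.05 log units; within the scatter) stays small. The estimate for compound 4 is 32000 nM with an expected range from 15000 nM to 65000 nM once measured.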

Compound 4, half-maximal inhibitory concentration: 24000 nM
Estimate against measurement, compound 4: 1.3-fold (0.12 log units) above; the range from low to high includes it.
By their numbers in this assay, from the lowest: compounds 4, 2, 3 and 1 (each within the scatter of the next).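

Among these compounds, this is the first pair of compounds that differ in one place only, so it gives a first direct reading for this position. In this assay, fluoro in place of hydrogen on an aromatic carbon, para to a large group, gives a 1.5-fold lower number from compound 3 to compound 4 (0.18 log units; within the scatter), so this small change does not separate the two compounds. No supporting evidence bears on this result. Going by these compounds, whether an amine or a carboxylic acid at this place would give a step beyond the scatter remains open, as does the effect of a longer chain there.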